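A few compounds are considered here, and "the series" means these few. Any claim that something is new, unique, unknown or untested is made for them only; others in the source may bear on it.

Compound 2 `CCCN(CC1CC1)c1cc(C)nc(N(CC)c2ccc(C(C)C)cc2Br)n1` gives 9 nM in an assay on isolated protein for binding affinity to corticotropin-releasing factor receptor 1 (Homo sapiens); a higher number here means a weaker inhibitor, a lower number a stronger inhibitor.
Compound 3 `CCN(CC)c1cc(C)nc(N(CC)c2ccc(I)cc2Br)n1` gives 9 nM.
Compound 1 `CCN(c1nc(C)cc(N2CCCCC2)n1)c1ccc(C(C)C)cc1Br` gives 29 nM.

On these numbers compound 2 stands level with compound 3, the two sharing the lowest number, while compound 1 sits higher. Compound 4 `CCCN(c1cc(C)nc(N(CC)c2ccc(C(C)C)cc2Br)n1)C1CC1` differs from compound 2 by cyclopropyl in place of cyclopropylmethyl on a nitrogen on an aromatic ring; seen one bond further out, (cyclopropylmethyl)(propyl)amino becomes cyclopropyl(propyl)amino. Going by the values given here, the only measured step at this position is a 3.2-fold lower number from compound 1 to compound 2 (0.51 log units; beyond the scatter), which set (cyclopropylmethyl)(propyl)amino in place of piperidin-1-yl and gave a modest gain. The present change is smaller and untested by any measured pair, so no shift beyond the scatter is expected in this assay. Compound 4 is therefore estimated at 12 nM, between 5 nM and 30 nM. The expected step is a 1.3-fold higher number from compound 2 to compound 4 (0.12 log units; within the scatter).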

Compound 4, inhibition constant: 5 nM
Compound 4: the middle estimate sits 2.4-fold (0.38 log units) above what was measured; the measured number falls inside the stated range.
By their numbers in this assay, from the lowest: compounds 4, 2 and 3 (each within the scatter of the next); then compound 1.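

In this assay, setting cyclopropyl in place of cyclopropylmethyl on this nitrogen gives a 1.8-fold lower number from compound 2 to compound 4 (0.26 log units; within the scatter), so removing that one carbon produces no clear change. The shift from the piperidin-1-yl of the earlier compound remains clear with the new group, at a 5.8-fold lower number from compound 1 to compound 4 (0.76 log units; beyond the scatter). No available measurement explains either step. Still open, from the compounds shown here alone, is whether cyclobutyl or a longer chain such as 2-methoxyethyl on this nitrogen, in place of cyclopropyl, would keep the number this low.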